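The source may hold more compounds than are shown below. What is called first, only, known or untested is meant among the compounds shown, and "the series" means these compounds.

Measured in an ADME assay on cells (Hepatocyte, Homo sapiens) for metabolic stability, with a stated time of 90 min; a higher number here means faster removal of the compound, a lower number slower removal:
compound 1 `CCC(CC)CNc1c(C(N)=O)cnc2ccc(C#N)cc12` gives 12 uL/min
compound 2 `NC(=O)c1cnc2ccc(-c3cccnc3)cc2c1NCC1CCCCC1` gives 40 uL/min
compound 3 `C[C@@H](Nc1c(C(N)=O)cnc2ccc(-c3cccnc3)cc12)C1CCOCC1` gives 14 uL/min

Compound 1 has the lowest of the three numbers; its gap to compound 3 lies within the scatter, its gap to compound 2 beyond it. For the measured compounds named here, the only single-point step measured, a 2.9-fold lower number from compound 2 to compound 3 (0.46 log units; beyond the scatter), alters the group on the ring nitrogen and leaves the aryl position untouched, so it does not bear directly on the change to compound 4.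

Compound 4 `CCC(CC)CNc1c(C(N)=O)cnc2ccc(-c3ccc(COC)cc3)cc12` differs from compound 1 as follows: 4-(methoxymethyl)phenyl in place of cyano on an aromatic carbon. Going by the values given here, no measured step at that position exists; compounds 2 and 3, which carry an aryl group there, span a range that straddles compound 1. A rise toward those numbers is therefore expected but uncertain, an estimated step of a 2.1-fold higher number from compound 1 to compound 4 (0.32 log units; beyond the scatter). Compound 4 is expected at 25 uL/min, within 10 uL/min to 60 uL/min.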

Compound 4, intrinsic clearance in a liver preparation (reported as CLH), per the amount of preparation that the assay uses: 21 uL/min
Compound 4: middle estimate off by 1.2-fold (0.08 log units), on the high side, within the range that was stated.
By their numbers in this assay, from the lowest: compounds 1, 3, 4 and 2 (each within the scatter of the next, the first and the last beyond it).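

In this assay, 4-(methoxymethyl)phenyl in place of cyano on this aromatic carbon gives a 1.8-fold higher number from compound 1 to compound 4 (0.24 log units; within the scatter): the position takes a group of 9 heavy atoms in place of one of 2 with no shift beyond the scatter. With the nitrogen substituent of compound 1 held fixed, the two groups cannot be told apart in this read-out. Nothing on hand accounts for this result.

Going by these compounds, whether the methoxymethyl group matters stays open: a plain phenyl, or a phenyl carrying an amine or a carboxylic acid, could read differently. Also open, on these data alone, is whether the same holds with other substituents on the ring nitrogen.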